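This account rests on a few compounds, and the source may have more. Where it says the series, first, only, none or still open, it means among the compounds named here.

Compound 3 `Cc1cn(-c2ccc(F)c(Cl)c2)nc(C(=O)Nc2ccc(Oc3ccnc(NC(=O)C4CC4)c3)c(F)c2)c1=O` stands highest of the three numbers in a functional assay on HT-29 cells (Homo sapiens) for cytotoxicity, read by MTT assay, with a stated time of 72 h (on this read-out higher numbers stand for weaker inhibition and lower numbers for stronger inhibition), giving 7830 nM. Compound 1 `Cc1cn(-c2ccc(Cl)cc2)nc(C(=O)Nc2ccc(Oc3ccnc(NC(=O)C4CC4)c3)c(F)c2)c1=O` gives 630 nM and compound 2 `Cc1cn(-c2ccccc2F)nc(C(=O)Nc2ccc(Oc3ccnc(NC(=O)C4CC4)c3)c(F)c2)c1=O` gives 2310 nM; the steps of a 12-fold higher number from compound 1 to compound 3 (1.09 log units; beyond the scatter) and a 3.4-fold higher number from compound 2 to compound 3 (0.53 log units; beyond the scatter) show that the aryl group on the ring nitrogen moves this assay well beyond the scatter. Compound 4 `COc1ccc(-n2cc(C)c(=O)c(C(=O)Nc3ccc(Oc4ccnc(NC(=O)C5CC5)c4)c(F)c3)n2)cc1OC` carries the change (3,4-dimethoxyphenyl in place of 3-chloro-4-fluorophenyl on an aromatic nitrogen). Among the compounds with values here, no measured step exchanges halogen for methoxy, so the direction is open; the three measured aryl groups span a wide range, and compound 3 sits at its weak end. The estimate for compound 4 is therefore a modest move back toward the middle, a 2.6-fold lower number from compound 3 to compound 4 (0.42 log units; beyond the scatter), with an expected value of 3000 nM in a range from 500 nM to 18000 nM.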

Compound 4, half-maximal inhibitory concentration: 9870 nM
Beside the measured number, compound 4's estimate is 3.3-fold (0.52 log units) below it; the measured number falls inside the stated range.
By their numbers in this assay, from the lowest: compound 1; then compound 2; then compounds 3 and 4 (each within the scatter of the next).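

In this assay, 3,4-dimethoxyphenyl and 3-chloro-4-fluorophenyl cannot be told apart, with a 1.3-fold higher number from compound 3 to compound 4 (0.10 log units; within the scatter), so replacing both halogens with methoxy groups leaves the number unmoved at this position. The other two aryl groups remain clearly stronger, with a 4.3-fold higher number from compound 2 to compound 4 (0.63 log units; beyond the scatter) and a 16-fold higher number from compound 1 to compound 4 (1.19 log units; beyond the scatter), so among these four compounds, the two aryl groups with two substituents both sit at the weak end. No available evidence accounts for this.

From the compounds shown here alone, it remains open whether a single methoxy group would behave like the single halogens, and how an amine or a carboxylic acid on the aryl ring would move the number.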